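The source may report more compounds than this note shows. Statements on the series, on what has been measured and on what is new or still open speak of the compounds shown alone.

Measured so far, in an assay on isolated protein for inhibition of histone deacetylase 4 (Homo sapiens), with a stated time of 1 h; a lower number here means a stronger inhibitor, a higher number a weaker inhibitor:

compound 1, `Cc1ccc(NC(=O)COc2ccc3cc(/C=C4/SC(=O)NC4=O)ccc3c2)cc1`, gives 1700 nM
compound 2, `CCOc1ccc2nc(NC(=O)COc3ccc4cc(/C=C5/SC(=O)NC5=O)ccc4c3)sc2c1`, gives 3600 nM

Compound 1 has the lower of the two half-maximal inhibitory concentrations; compound 2 stands higher, and the gap between the two lies beyond the usual scatter. The two differ in more than one place, so nothing is computed as a single step between them; the pair shows only that the amide substituent region tolerates change with a measurable shift in this assay.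

The unmeasured compound 3, `O=C(COc1ccc2cc(/C=C3/SC(=O)NC3=O)ccc2c1)Nc1ccc(Br)cc1F`, keeps the shared core of compound 1 and changes only the group on the amide-type nitrogen: 4-bromo-2-fluorophenyl in place of 4-methylphenyl on an amide-type nitrogen. Among the compounds with values here, no measured pair isolates this kind of exchange, so there is no reference step to lean on. A step within the scatter, or a small shift in either direction, is the expectation for a 1.1-fold lower number from compound 1 to compound 3 (0.05 log units; within the scatter). Compound 3 is therefore estimated at 1500 nM in this assay, with a range from 500 nM to 4500 nM to cover the uncertainty of an untested exchange.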

Compound 3, half-maximal inhibitory concentration: 1900 nM
The estimate for compound 3 lay 1.3-fold (0.10 log units) below the measured number, and the stated range covers the measured number.
By their numbers in this assay, from the lowest: compounds 1, 3 and 2 (each within the scatter of the next, the first and the last beyond it).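

Compound 3 gives the series its first comparison in one place, on the amide-type nitrogen whose other neighbour is the carbonyl carbon. In this assay, within the data shown here, the exchange of 4-methylphenyl for 4-bromo-2-fluorophenyl is a 1.1-fold higher number from compound 1 to compound 3 (0.05 log units; within the scatter), so this read-out does not separate the two groups, although the earlier pair showed only that compounds differing in more than one place can lie apart. On this evidence, bromine and fluorine on the ring can replace the methyl group with the number staying in the same range, and no accompanying measurement speaks to the basis of this result.

With both substituents changed at once, the separate contributions of the bromine and the fluorine remain unresolved, and 4-bromophenyl and 2-fluorophenyl alone would be needed to divide them. Also open, going by these compounds, is whether a departure from a substituted phenyl ring on this nitrogen, such as a cyclohexyl group, a longer alkyl chain or a phenyl ring bearing a carboxylic acid or an amine, would move the number beyond the scatter.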